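Removing One Hydroxy from the Catechol Side of Compound 2

This account rests on a few compounds, and the source may have more. Where it says the series, first, only, none or still open, it means among the compounds named here.

Compound 1 `O=C(/C=C/c1ccccc1)c1ccc2occc2c1O`: 20.8%
Compound 2 `O=C(/C=C/c1ccc(O)c(O)c1)c1cc2ccoc2cc1O`: 62.7%
Compound 3 `O=C(/C=C/c1ccccc1)c1cc2ccoc2cc1O`: 67.6%

Of the compounds shown here, three have been read in an assay on isolated protein for inhibition of lysosomal alpha-glucosidase (Rattus norvegicus), read by spectrophotometry, with a stated time of 5 min, tested at 25 ug/mL; on this read-out higher numbers stand for more inhibition at the one concentration tested (going by the name of the read-out) and lower numbers for less inhibition. Compound 2 stands well above compound 1, a gap beyond the usual scatter, and sits within the scatter of compound 3, so no order between compound 2 and compound 3 can be claimed. Compound 1, whose hydroxy and ring fusion are arranged differently on the shared core, is the only one of the three that falls clearly lower.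

The next compound is compound 4 `O=C(/C=C/c1ccc(O)cc1)c1cc2ccoc2cc1O`, which differs from compound 2 by one change: hydrogen in place of hydroxy on an aromatic carbon. Since compound 2, with two hydroxy groups on that ring, and compound 3, with none, give readings within the scatter of one another in this assay, a single hydroxy in between is not expected to move the number beyond the scatter in either direction. Compound 4 is therefore estimated at 64%, with a range from 50% to 78%. The step expected from this estimate is a number 1.3 percentage points higher from compound 2 to compound 4 (within the scatter), a change not beyond the scatter.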

Compound 4, a percentage reported as inhibition, at one concentration (the size of the read-out at that concentration, not a potency): 8.77%
Compound 4: middle estimate off by 55.2 percentage points, on the high side; the measured number lies below the stated range.
By their numbers in this assay, from the lowest: compound 4; then compound 1; then compounds 2 and 3 (each within the scatter of the next).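

In this assay, the hydroxy that leaves compound 2, ortho to a hydroxy group and meta to a large group, proves to matter a great deal: hydrogen in its place gives a number 53.9 percentage points lower from compound 2 to compound 4 (beyond the scatter). Read from the other side, hydroxy in place of hydrogen on an aromatic carbon gives a number 58.8 percentage points lower from compound 3 to compound 4 (beyond the scatter), so on this ring a single hydroxy does not fall in with the compounds on either side of it, and the effect of one change depends on what else the ring carries. Nothing available accounts for this drop.

The compounds shown leave open whether the high reading of compound 2 needs a hydroxy at this position specifically or would survive with a methoxy group or a fluorine atom there. They also leave open whether a single hydroxy elsewhere on the ring would give the same low reading.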